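The source may hold more compounds than are shown below. What is called first, only, known or untested is meant among the compounds shown, and "the series" means these compounds.

Compound 1 `COc1cc(-c2nnc(SCC(=O)c3ccc(Br)cc3)n2N)cc(OC)c1OC` and compound 2 `COc1cccc(NC(=O)CSc2nnc(-c3cc(OC)c(OC)c(OC)c3)n2N)c1` share a core and differ only in the group on the carbonyl carbon: the 4-bromophenyl of compound 1 becomes a (3-methoxyphenyl)amino in compound 2. In a functional assay on HeLa cells (Homo sapiens) for antiproliferative activity, read by MTT assay, with a stated time of 48 h (on this read-out higher numbers stand for weaker inhibition and lower numbers for stronger inhibition), compound 1 gives 10400 nM, and in the same test compound 2 gives 4020 nM. The step of a 2.6-fold lower number from compound 1 to compound 2 (0.41 log units; beyond the scatter) is therefore a modest gain, and on the two numbers seen so far compound 2 stands lowest.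

Compound 3 `COc1cc(-c2nnc(SCC(=O)NCc3ccc(C)cc3)n2N)cc(OC)c1OC` keeps the amide of compound 2 but carries 4-methylbenzyl in place of 3-methoxyphenyl on an amide-type nitrogen. Within the data shown here, the only measured step, the one from compound 1 to compound 2, exchanged a ketone for an amide; it concerns a different kind of change and does not bear directly on swapping one aromatic substituent on the amide nitrogen for another. Among the measured compounds shown here, with no measured step of this kind, the expectation for compound 3 is a number close to that of compound 2, a step of a 1.2-fold higher number from compound 2 to compound 3 (0.09 log units; within the scatter), no larger than the scatter. The estimate for compound 3 is 5000 nM, with a range from 1500 nM to 16000 nM.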

Compound 3, half-maximal inhibitory concentration: > 100000 nM
Compound 3 was reported as a limit (the forecaster's own chance of this, stated with the estimate: 5%); middle value at least 20-fold (1.30 log units) away from the limit.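

Exchanging 3-methoxyphenyl for 4-methylbenzyl on the amide-type nitrogen is far from a neutral swap: in this assay it gives an at least 24-fold higher number from compound 2 to compound 3 (1.39 log units; beyond the scatter), so the group on this nitrogen can strongly change the read-out. Compound 3 is reported only as a limit of the assay, not as an exact number: the limit of > 100000 nM in this assay, at which 1 of the 3 values shown sits. Replacing the 4-bromophenyl on the carbonyl carbon with (4-methylbenzyl)amino gives an at least 9.6-fold higher number from compound 1 to compound 3 (0.98 log units; beyond the scatter), whereas (3-methoxyphenyl)amino moved the number the other way, so an amide at this carbonyl does not by itself set the direction of the change.

In this pair, the benzyl form and the swap of methoxy for methyl arrive together, and their separate contributions to the loss remain unresolved; a 4-methylphenyl or a 3-methoxybenzyl on the same nitrogen would pull them apart. Going by these compounds, the true value of compound 3 also remains open, and so does whether a smaller group on this nitrogen, such as methyl, would give a number closer to that of compound 2.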